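The compounds below may be only part of what the source reports. "The series", "measured", "known", "first", "only" and "open" are said of these compounds alone.

Working notes on the series.

Compound 1 `COc1ccc2oc(SCCC(=O)N3CCCC3)nc2c1` carries a methoxy on the core and is tested in an ADME assay on microsomes from liver (Mus musculus) for metabolic stability, read by LC-MS, using NADPH, with a stated time of 45 min, tested at 0.5 uM (a higher number here means faster removal of the compound, a lower number slower removal), where compound 1 gives 198 mL/min/g. Two numbers exist so far, and compound 1 stands as the higher of them. The other belongs to compound 3 `CN1CCN(C(=O)CCSc2nc3cc(Cl)ccc3o2)CC1`, which in this assay gives 41.5 mL/min/g, a gap beyond the usual scatter; compound 3 differs from compound 1 in more than one place, so its lower number cannot be tied to any single change. Compound 2 `CN(CCC(=O)N1CCCC1)c1nc2cc(Cl)ccc2o1` has no number in this assay, its result being "not determined" (no result reported). Among the measured compounds shown here, no pair among the measured compounds differs in a single place, so no clean step is available.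

Compound 4 `O=C(CCSc1nc2cc(F)ccc2o1)N1CCCC1` is the next entry for this assay. Against compound 1 the change is fluoro in place of methoxy on an aromatic carbon. For the measured compounds named here, with no matching step measured, the expectation rests on compound 1 alone, and a step downward of moderate size is expected, larger than the scatter but uncertain in size. Compound 4 is therefore expected to give about 90 mL/min/g in this assay, within a range of 40 mL/min/g to 200 mL/min/g. The expected step is a 2.2-fold lower number from compound 1 to compound 4 (0.34 log units; beyond the scatter).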

Compound 4, intrinsic clearance in a liver preparation (reported as CLH), per the amount of preparation that the assay uses: 115 mL/min/g
For compound 4 the middle estimate is 1.3-fold (0.11 log units) below the measured one; low and high end bracket the measured number.
By their numbers in this assay, from the lowest: compound 3; then compounds 4 and 1 (each within the scatter of the next).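

In this assay, among the compounds shown here, fluoro in place of methoxy on an aromatic carbon gives the only clean step so far, a 1.7-fold lower number from compound 1 to compound 4 (0.24 log units; within the scatter), so this change at this position does not separate the two compounds in the read-out. The step also leaves the gap seen for compound 3 unassigned, as compound 3 differs from compound 4 in more than one place and this single change cannot be read across to it. No measurement available here bears on why the swap leaves the number within the scatter.

Still open, going by these compounds, is whether a different group on this aromatic carbon, such as a nitrile or a trifluoromethyl, would produce a step beyond the scatter from compound 1 or compound 4. Also open, on these data alone, is how much of the number for compound 3, at 41.5 mL/min/g, goes with the chloro on the core and how much with the amine part of its amide, a question that single changes on the shared core would be needed to separate.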